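Acetyl in Place of Phenyl: Outlook on Cell Toxicity

This account rests on a few compounds, and the source may have more. Where it says the series, first, only, none or still open, it means among the compounds named here.

Three compounds sharing one core were tested in an ADME assay on HepG2 cells (Homo sapiens) for cytotoxicity, read by luminescence, with a stated time of 72 h; on this read-out lower numbers stand for an effect already at smaller amounts and higher numbers for an effect only at larger amounts of compound. Compound 1 `CCOC(=O)c1c(-c2ccccc2)[nH]c2cc(OC)ccc2c1=O` is the simplest member; in this assay compound 1 reaches only the limit of the assay, > 21500 nM. Compound 2 `CCOC(=O)c1c(-c2cccc(-c3ccccc3)c2)[nH]c2cc(OC)ccc2c1=O` carries an added phenyl; in this assay compound 2 likewise reaches only the limit, > 21500 nM. Compound 3 `CCOC(=O)c1c(-c2cccc(OCC)c2)[nH]c2cc(OC)ccc2c1=O` carries an ethoxy instead; in this assay compound 3 again gives only the limit, > 21500 nM. Since every value is a limit and not a number, the steps a step that the two limits leave unreadable from compound 1 to compound 2, a step that the two limits leave unreadable from compound 1 to compound 3 and a step that the two limits leave unreadable from compound 2 to compound 3 cannot be sized; all three compounds stand together at the limit of > 21500 nM in this assay, at which 3 of the 3 values shown sit. Compound 4 `CCOC(=O)c1c(-c2cccc(C(C)=O)c2)[nH]c2cc(OC)ccc2c1=O` is the next member, obtained from compound 2 by the change (acetyl in place of phenyl on an aromatic carbon). Going by the values given here, no measured step gives a size for such a change, and nothing measured rises above the limit. The step of a number no higher from compound 2 to compound 4 (the limit leaves the size open) is therefore expected to stay within the scatter. Compound 4 is expected to give about 21500 nM, within 10000 nM to 60000 nM, most likely again only as a limit.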

Compound 4, half-maximal effective concentration: > 21500 nM
Compound 4 ended at the assay's limit; the forecaster's own chance of this, stated with the estimate: 75%; the middle value sits exactly at the limit.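

Compound 4 gives only a limit and not a number, as do compound 1, compound 2 and compound 3, so no step involving compound 4 can be read: the limit of > 21500 nM in this assay, at which 4 of the 4 values shown sit.

The compounds shown leave open at what concentration any of them would reach a half-maximal effect in this assay, and whether phenyl, ethoxy or acetyl changes that concentration.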